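Swapping a ring on a nitrogen of the compound with the lowest number

The source may hold more compounds than are shown below. What is called first, only, known or untested is meant among the compounds shown, and "the series" means these compounds.

Of the compounds shown here, three have been measured in a functional assay on M14 cells (Homo sapiens) for inhibition, read by sulforhodamine B assay, with a stated time of 48 h, tested at 10 uM; on this read-out higher numbers stand for more inhibition at the one concentration tested (going by the name of the read-out) and lower numbers for less inhibition. Compound 1 `c1ccc(-c2cn3ccnc3c(-c3ccc4ncn(C5CCCCC5)c4c3)n2)cc1` gives 38.2%, compound 2 `COc1ccc(-c2cn3ccnc3c(-c3ccc4ncn(C5CCCCC5)c4c3)n2)cc1` gives 89.2%, and compound 3 `c1cn2cc(-c3ccc4c(c3)ncn4C3CCCCC3)nc(-c3ccc4ncn(C5CCCCC5)c4c3)c2n1` gives 6.98%. Compound 3 stands lowest of the three: compound 1 lies closest to it, while compound 2 lies furthest away, and both gaps are beyond the scatter. Among the compounds with values here, the one step between measured compounds that differ in a single place, a number 51 percentage points higher from compound 1 to compound 2 (beyond the scatter), came from a methoxy in place of hydrogen on an aromatic carbon.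

Compound 4 `c1ccc(Cn2cnc3ccc(-c4nc(-c5ccc6c(c5)ncn6C5CCCCC5)cn5ccnc45)cc32)cc1` has not yet been measured in this assay. It differs from compound 3 in one place: benzyl in place of cyclohexyl on an aromatic nitrogen. Cyclohexyl leaves and benzyl enters, on an aromatic nitrogen of a five-membered aromatic ring with two nitrogen atoms, part of a fused system of two rings.

Within the data shown here, no measured step bears on this change. Among the measured compounds shown here, the only step seen, from compound 1 to compound 2, concerns a different group at a different place, so it gives no guide for the exchange of one ring for another on a ring nitrogen. With nothing to indicate a direction, the expected step of a number 8 percentage points higher from compound 3 to compound 4 (within the scatter) is one without a clear size beyond the scatter. Compound 4 is therefore estimated at 15%, within a range from 0% to 45%.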

Compound 4, a percentage reported as inhibition, at one concentration (the size of the read-out at that concentration, not a potency): -4.44%
Estimate against measurement, compound 4: 19.4 percentage points above; the whole stated range lies above it.
By their numbers in this assay, from the lowest: compound 4; then compound 3; then compound 1; then compound 2.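

In this assay the group on this aromatic nitrogen turns out to matter: benzyl in place of cyclohexyl gives a number 11.4 percentage points lower from compound 3 to compound 4 (beyond the scatter) and so moves the number beyond the scatter, which the earlier step, a methoxy change at a different place, could not show. Within the data shown here, the step is modest and runs downward from a compound that already stood low, and with compound 4 at -4.44% on this read-out, benzyl brings back no inhibition in this pair. Nothing available explains why the number fell with this exchange, and the finding rests on this single pair.

From the compounds shown here alone, it remains open whether other groups on this nitrogen, such as methyl, a longer alkyl chain or a chain ending in an amine, would raise the number or lower it further. Going by these compounds, it is equally open whether the same exchange would have a similar effect in compound 1 or compound 2, where the aromatic ring without or with methoxy takes the place of the second cyclohexyl-bearing unit.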